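Trifluoromethyl in Place of Cyano on Compound 4

A few compounds are considered here, and "the series" means these few. Any claim that something is new, unique, unknown or untested is made for them only; others in the source may bear on it.

The measured compounds, all sharing one core and differing only in the group on one aromatic carbon:

Compound 1, `Nc1nc(-c2ccco2)nc2sc(CN3CC=CC3)cc12`: in an assay on CHO-K1 cells for antagonist activity at adenosine receptor A1 (Homo sapiens), read by a beta-galactosidase reporter, with stated times of 15 min and 6 h (on this read-out lower numbers stand for stronger inhibition and higher numbers for weaker inhibition), compound 1 gives 290 nM.
Compound 2, `Nc1nc(-c2ncco2)nc2sc(CN3CC=CC3)cc12`: in this assay compound 2 gives 3890 nM.
Compound 3, `N#Cc1cccc(-c2nc(N)c3cc(CN4CC=CC4)sc3n2)c1`: in this assay compound 3 gives 2070 nM.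

Compound 3 stands second highest of these three numbers. Its nearest neighbour is compound 2, and the step of a 1.9-fold lower number from compound 2 to compound 3 (0.27 log units; within the scatter) lies within the scatter, so the two cannot be ordered. Its furthest neighbour is compound 1, and the step of a 7.1-fold higher number from compound 1 to compound 3 (0.85 log units; beyond the scatter) lies beyond the scatter, as does a 13-fold higher number from compound 1 to compound 2 (1.13 log units; beyond the scatter).

Compound 4, `Nc1nc(-c2cccc(C(F)(F)F)c2)nc2sc(CN3CC=CC3)cc12`, differs from compound 3 by trifluoromethyl in place of cyano on an aromatic carbon. Among the compounds with values here, none of the measured steps bears on this change directly: each of them exchanges the whole group on that aromatic carbon, whereas here the six-membered ring stays and only its substituent changes. The closest guide is the small step of a 1.9-fold lower number from compound 2 to compound 3 (0.27 log units; within the scatter), which did not leave the scatter. Compound 4 is therefore expected to show no step beyond the scatter, a 1.0-fold lower number from compound 3 to compound 4 (0.01 log units; within the scatter). The estimate for compound 4 in this assay is 2000 nM, with a range from 700 nM to 6000 nM.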

Compound 4, inhibition constant: 2960 nM
Compound 4: middle estimate off by 1.5-fold (0.17 log units), on the low side, and the stated range covers the measured number.
By their numbers in this assay, from the lowest: compound 1; then compounds 3, 4 and 2 (each within the scatter of the next).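

In this assay, trifluoromethyl in place of cyano gives a 1.4-fold higher number from compound 3 to compound 4 (0.16 log units; within the scatter), so compound 3 and compound 4 cannot be ordered. Unlike the earlier steps, this one keeps the six-membered aromatic ring and alters only its substituent, showing that a group of four heavy atoms with no hydrogen-bond acceptor can replace one of two heavy atoms with one hydrogen-bond acceptor while the numbers stay within the scatter of each other. Nothing measured here explains this result.

The compounds shown leave open whether an amine or a carboxylic acid at the same place on that ring would also stay within the scatter of compound 3. They also leave open whether a longer chain there would do so.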